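Naphthalen-1-yl for phenyl on the thiocarbonyl nitrogen

The source may hold more compounds than are shown below. What is called first, only, known or untested is meant among the compounds shown, and "the series" means these compounds.

Two compounds of the series carry a reading in a functional assay on HeLa cells (Homo sapiens) for antiproliferative activity, with a stated time of 24 h; a higher number here means a weaker inhibitor, a lower number a stronger inhibitor. Compound 1 `NC(=O)c1c(NC(=O)c2ccccc2Cl)sc2c1CCN(Cc1ccccc1F)C2` gives > 50000 nM, which is a limit of the assay rather than a number. Among the compounds with values here, compound 2 `NC(=O)c1c(NC(=O)c2ccccc2Cl)sc2c1CCN(C(=S)Nc1ccccc1)C2` gives 46700 nM in this assay and so holds the only actual number among the two values shown. Within the data shown here, the single measured step, an at least 1.0-fold lower number from compound 1 to compound 2 (0.02 log units; that floor lies within the scatter), starts from the limit of > 50000 nM in this assay, at which 1 of the 2 values shown sits, and lies within the scatter, so it offers no direction on its own. Compound 3 `NC(=O)c1c(NC(=O)c2ccccc2Cl)sc2c1CCN(C(=S)Nc1cccc3ccccc13)C2` differs from compound 2 by naphthalen-1-yl in place of phenyl on an amide-type nitrogen; the same difference, cut one bond further out, reads anilino to (naphthalen-1-yl)amino. Among the measured compounds shown here, no measured step alters this aryl group, so nothing here bears on the change beyond the weak range that compound 2 itself occupies. The expectation is therefore a step of a 1.2-fold lower number from compound 2 to compound 3 (0.07 log units; within the scatter), not beyond the scatter. Compound 3 is estimated at 40000 nM in this assay, with a range from 15000 nM to 100000 nM, and a sizeable chance that only a limit is returned.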

Compound 3, half-maximal inhibitory concentration: 30800 nM
The estimate for compound 3 lay 1.3-fold (0.11 log units) above the measured number; the range from low to high includes it.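

In this assay, naphthalen-1-yl in place of phenyl on the amide-type nitrogen gives a 1.5-fold lower number from compound 2 to compound 3 (0.18 log units; within the scatter), so the two aryl groups cannot be told apart at this position. Within the data shown here, this is the first step that can be read as a true comparison of two numbers, and it shows that a second six-membered aromatic ring of carbon on this nitrogen leaves the reading within the scatter of the phenyl compound. Compound 1 remains a limit of the assay and not a number: the limit of > 50000 nM in this assay, at which 1 of the 3 values shown sits.

On these data alone, whether a pyridyl group, a cyclohexyl group or a longer alkyl chain on this nitrogen would move the reading beyond the scatter stays open, as does the effect of a carbonyl in place of the thiocarbonyl. All three compounds also keep the same shared core, which leaves open whether a change elsewhere, such as an amine or a carboxylic acid on the benzoyl ring, would shift the reading in this assay.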